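A few compounds are considered here, and "the series" means these few. Any claim that something is new, unique, unknown or untested is made for them only; others in the source may bear on it.

In a functional assay on NCI-H460 cells (Homo sapiens) for inhibition, with a stated time of 72 h (a lower number here means a stronger inhibitor, a higher number a weaker inhibitor), compound 1 `COc1cc(C(=O)n2ccc3ccccc32)cc(OC)c1OC` reads > 10000 nM and this is a limit of the assay, not a number. Compound 3 `COc1cc(C(=O)c2ccc3[nH]ccc3c2)cc(OC)c1OC` gives 112 nM and compound 2 `COc1cc(C(=O)c2cccc3[nH]ccc23)cc(OC)c1OC` gives 53.8 nM as the lowest number shown, with the gap between these two lying beyond the usual scatter. Compound 4 `COc1cc(C(=O)c2cccc3c2ccn3C)cc(OC)c1OC` differs from compound 2 by one change, methyl in place of hydrogen on an aromatic nitrogen. For the measured compounds named here, no measured pair shows this change, so the expectation is loose: a modest move toward a weaker inhibitor, possibly no larger than the scatter. The expected 1.7-fold higher number from compound 2 to compound 4 (0.22 log units; within the scatter) is therefore small. In this assay the estimate for compound 4 is 90 nM (expected range 25 nM to 300 nM).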

Compound 4, half-maximal inhibitory concentration: 28.8 nM
Beside the measured number, compound 4's estimate is 3.1-fold (0.49 log units) above it; the measured number falls inside the stated range.
By their numbers in this assay, from the lowest: compounds 4 and 2 (each within the scatter of the next); then compound 3. At a limit, above all of these: compound 1.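

In this assay, methyl in place of hydrogen on an aromatic nitrogen gives a 1.9-fold lower number from compound 2 to compound 4 (0.27 log units; within the scatter), so this is the first step shown at this position. Compound 2 and compound 4 cannot be told apart, which shows that a hydrogen on this nitrogen is not needed for a number this low. Nothing shown explains the size of this step. From the compounds shown here alone, whether an ethyl group, a longer chain or an acetyl group on this nitrogen would read the same stays open. So does the effect of the same methyl on compound 3.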